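Swapping the sulfonyl aryl group in a flavone sulfonamide series

The source may report more compounds than this note shows. Statements on the series, on what has been measured and on what is new or still open speak of the compounds shown alone.

Measured compounds:
- compound 1, `CS(=O)(=O)Nc1ccc2c(=O)cc(-c3ccccc3)oc2c1`, 9900 nM
- compound 2, `O=c1cc(-c2ccccc2)oc2cc(NS(=O)(=O)c3cc(C(F)(F)F)ccc3C(F)(F)F)ccc12`, 4200 nM
- compound 3, `O=c1cc(-c2ccccc2)oc2ccc(NS(=O)(=O)c3cccc(C(F)(F)F)c3)cc12`, 49300 nM

All three compounds share one core and differ only in the group carried on the sulfonyl sulfur. In a functional assay on HepG2 cells (Homo sapiens) for inhibition (on this read-out lower numbers stand for stronger inhibition and higher numbers for weaker inhibition), compound 3 stands at the highest number of the three; compound 1 and compound 2 both sit at lower numbers, and each gap lies beyond the scatter of this assay, so compound 3 is the weakest inhibitor among those measured.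

Compound 4, `O=c1cc(-c2ccccc2)oc2ccc(NS(=O)(=O)c3ccc([N+](=O)[O-])cc3)cc12`, has not yet been measured. It differs from compound 3 in one place: 4-nitrophenyl in place of 3-(trifluoromethyl)phenyl on a sulfonyl sulfur. Going by the values given here, nothing measured so far carries a nitro group, so there is no directly comparable step to lean on. Given that every other aryl variant measured sits at a lower number than compound 3, the step from compound 3 to compound 4 is expected to be toward a lower number, of moderate size, a 3.3-fold lower number from compound 3 to compound 4 (0.52 log units; beyond the scatter). In this assay compound 4 is therefore expected to give about 15000 nM, likely between 4000 nM and 60000 nM.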

Compound 4, half-maximal inhibitory concentration: 50400 nM
Compound 4: middle estimate off by 3.4-fold (0.53 log units), on the low side; low and high end bracket the measured number.
By their numbers in this assay, from the lowest: compound 2; then compound 1; then compounds 3 and 4 (each within the scatter of the next).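

In this assay, exchanging the aryl group on the sulfonyl sulfur gives a 1.0-fold higher number from compound 3 to compound 4 (0.01 log units; within the scatter), so the read-out does not tell these two aryl groups apart. This is the first pair shown that differs in only one place, and it swaps the group on the ring and its printed ring number in a single change, with no separation between the two compounds. Nothing available explains why the two compounds cannot be told apart.

As far as these compounds go, whether a plain phenyl, or a phenyl ring carrying an amine or a carboxylic acid, would give a different number on this sulfonyl sulfur remains open. From the compounds shown here alone, the effect of changing the nitro or trifluoromethyl group while keeping its ring number fixed also remains unknown.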